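The source may hold more compounds than are shown below. What is called first, only, known or untested is meant among the compounds shown, and "the series" means these compounds.

Measured so far in an ADME assay (liver) for pharmacokinetics, with Liver microsome (Rattus norvegicus) as the target, read by LC-MS, using microsomes, tested at 2 uM; a lower number here means slower removal, a higher number faster removal of the compound
- compound 1 `Cc1c(C(=O)N[C@@H]2CCCC[C@H]2O)cc(-c2cc(C(F)(F)F)ccc2Cl)n1CC1CCCCC1` gives 1.32 mL/min/kg
- compound 2 `O=C(N[C@@H]1CCCC[C@H]1O)c1cnc(OC2CCCC2)c(-c2cc(C(F)(F)F)ccc2Cl)c1` gives 0.367 mL/min/kg
- compound 3 `O=C(N[C@@H]1CCCC[C@H]1O)c1cnc(Oc2ccccc2)c(-c2ccc(Cl)cc2)c1` gives 0.353 mL/min/kg

Compound 3 and compound 2 lie within the scatter of each other, while compound 1 gives a higher number, beyond the scatter. The next entry is compound 4 `O=C(N[C@@H]1CCCC[C@H]1O)c1cnc(OCC2CC2)c(-c2ccc(Cl)cc2)c1`, which keeps the core of compound 3 and carries cyclopropylmethyl in place of phenyl on an oxygen on an aromatic ring, or phenoxy to cyclopropylmethoxy: cyclopropylmethyl in place of phenyl on an oxygen on an aromatic ring.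

Going by the values given here, no measured pair isolates this change, so the expectation is loose. Compound 2 also has a non-aromatic group on that oxygen, though it differs elsewhere too, and it gives 0.367 mL/min/kg in this assay. That offers no sign of a large rise. A small move to a higher number, within the scatter, is expected, and the estimated step is a 1.4-fold higher number from compound 3 to compound 4 (0.15 log units; within the scatter). For compound 4 the estimated value is 0.5 mL/min/kg, with an expected range of 0.25 mL/min/kg to 1.1 mL/min/kg.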

Compound 4, clearance: 0.064 mL/min/kg
Compound 4: middle estimate off by 7.8-fold (0.89 log units), on the high side; the whole stated range lies above it.
By their numbers in this assay, from the lowest: compound 4; then compounds 3 and 2 (each within the scatter of the next); then compound 1.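

In this assay, going by these compounds alone, the group on an oxygen on an aromatic ring emerges as a sensitive point on this core: cyclopropylmethyl in place of phenyl gives a 5.5-fold lower number from compound 3 to compound 4 (0.74 log units; beyond the scatter), a step beyond the scatter and the first change read in one place only. An aromatic ring on that oxygen is thus not required for a low number, and compound 4 gives 0.064 mL/min/kg with cyclopropylmethyl there. Nothing at hand accounts for the size of this step.

From the compounds shown here alone, with one pair, it stays open whether the step reflects the loss of phenyl or something particular to cyclopropylmethyl. Going by these compounds, how a straight butyl chain or an ethyl chain ending in an amine on that oxygen would read in this assay also remains open.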